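A few compounds are considered here, and "the series" means these few. Any claim that something is new, unique, unknown or untested is made for them only; others in the source may bear on it.

Measured compounds:
- compound 1 `CCCCCCOc1ccc2c(Cl)ccnc2c1`: 2660 nM
- compound 2 `Clc1ccnc2cc(OCc3ccccc3)ccc12`: 3270 nM
- compound 3 `Clc1ccnc2cc(OCCc3ccccc3)ccc12`: 3380 nM

All three compounds were tested in a functional assay on DLD-1 cells (Homo sapiens) for cytotoxicity, read by MTT assay, with a stated time of 48 h; on this read-out higher numbers stand for weaker inhibition and lower numbers for stronger inhibition. Compound 1 cannot be set apart from the others on these numbers: the step of a 1.2-fold higher number from compound 1 to compound 2 (0.09 log units; within the scatter) and the step of a 1.3-fold higher number from compound 1 to compound 3 (0.10 log units; within the scatter) are both within the scatter, so the three values are indistinguishable for practical purposes.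

Compound 4 `CC(C)Oc1ccc2c(Cl)ccnc2c1` has not yet been measured in this assay. It differs from compound 1 in one place: isopropyl in place of hexyl on an oxygen on an aromatic ring. The two measured steps tell something about how tolerant this position is. Swapping part of the chain for a phenyl ring, either close to the oxygen as in compound 2 or one carbon further along as in compound 3, left the number essentially unchanged. For the measured compounds named here, neither step, however, shortens the group as the change to compound 4 does, so there is no direct precedent for removing most of the chain. Given that the position accepted two rather different groups without a shift beyond the scatter, the expected step of a 1.9-fold higher number from compound 1 to compound 4 (0.27 log units; within the scatter) is modest, with a slight lean toward a higher number. The estimate for compound 4 is 5000 nM, with a range from 1500 nM to 16000 nM.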

Compound 4, half-maximal inhibitory concentration: 3240 nM
Beside the measured number, compound 4's estimate is 1.5-fold (0.19 log units) above it; the range from low to high includes it.
By their numbers in this assay, from the lowest: compounds 1, 4, 2 and 3 (each within the scatter of the next).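

Cutting the group on the oxygen from hexyl, with 6 heavy atoms, to the branched isopropyl, with 3, gives a 1.2-fold higher number from compound 1 to compound 4 (0.09 log units; within the scatter) in this assay, a change that stays within the scatter. The earlier steps only replaced part of the chain with a phenyl ring, whereas this one shows that compound 4 keeps a number indistinguishable from that of compound 1 with a much shorter group, so among these compounds neither the length of the group nor a branch in it separates the values. Nothing on hand explains why the values stay so close across these groups.

All the groups on this oxygen so far are made of carbon and hydrogen alone, which leaves open whether an amine or a carboxylic acid at the end of the chain would shift the number beyond the scatter. Also open, as far as these compounds go, are the smaller extreme, a methyl group or a free hydroxyl in place of the ether, and whether changing the shared core would matter more than changing this chain.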